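A few compounds are considered here, and "the series" means these few. Any claim that something is new, unique, unknown or untested is made for them only; others in the source may bear on it.

Compound 2 `Cn1cc(/C=C2/C(=O)Nc3ccccc32)c2cc(Nc3nccc(-c4cccnc4)n3)ccc21` gives 69800 nM in an ADME assay on RWPE-1 cells (Homo sapiens) for cytotoxicity, read by MTT assay, with a stated time of 48 h (a higher number here means a weaker inhibitor, a lower number a stronger inhibitor), the higher of the two numbers recorded so far. Compound 1 `Cn1cc(/C=C2/C(=O)Nc3ccccc32)c2cc(Nc3nccc(-c4ccc(Cl)cc4)n3)ccc21` gives 41100 nM in this assay, and the step of a 1.7-fold higher number from compound 1 to compound 2 (0.23 log units; within the scatter) is within the scatter, so the two stand together. Compound 3 `Cn1cc(/C=C2/C(=O)Nc3ccccc32)c2cc(Nc3nccc(-c4cccs4)n3)ccc21` is obtained from compound 2 by thiophen-2-yl in place of pyridin-3-yl on an aromatic carbon. Within the data shown here, the only step that bears on this change is the swap of the same aryl group from compound 1 to compound 2, which stayed within the scatter, so no shift beyond the scatter is expected in this assay. Compound 3 is therefore estimated at 55000 nM, with a range of 20000 nM to 150000 nM, the expected step being a 1.3-fold lower number from compound 2 to compound 3 (0.10 log units; within the scatter).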

Compound 3, half-maximal inhibitory concentration: 64900 nM
Compound 3: middle estimate off by 1.2-fold (0.07 log units), on the low side; the measured number falls inside the stated range.
By their numbers in this assay, from the lowest: compounds 1, 3 and 2 (each within the scatter of the next).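

In this assay, the steps of a 1.1-fold lower number from compound 2 to compound 3 (0.03 log units; within the scatter) and a 1.6-fold higher number from compound 1 to compound 3 (0.20 log units; within the scatter) both lie within the scatter, so a five-membered aromatic ring with sulfur now joins the six-membered aryl groups. On this aromatic carbon next to the ring nitrogen, 4-chlorophenyl, pyridin-3-yl and thiophen-2-yl all stand together. No measured evidence is available to explain this result. Open, on these data alone, is whether a non-aromatic group on this carbon, such as an amine, a carboxylic acid or a longer alkyl chain, would give a step beyond the scatter.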